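The source may hold more compounds than are shown below. What is called first, only, known or untested is meant among the compounds shown, and "the series" means these compounds.

Measured compounds in a functional assay on A549 cells (Homo sapiens) for antiproliferative activity, read by MTT assay; a higher number here means a weaker inhibitor, a lower number a stronger inhibitor:

Compound 1, `Cn1c(=O)c(=O)n(C2CCCC2)c2nc(N/N=C/c3ccc(Cl)cc3)ncc21`: compound 1 gives 6890 nM
Compound 2, `COc1cccc(/C=N/Nc2ncc3c(n2)n(C2CCCC2)c(=O)c(=O)n3C)c1`: compound 2 gives 27400 nM
Compound 3, `Cc1ccc(/C=N/Nc2ncc3c(n2)n(C2CCCC2)c(=O)c(=O)n3C)cc1C`: compound 3 gives 30200 nM

Compound 3 stands at the highest of the three numbers. Compound 2 lies within the usual scatter of it, so the two cannot be ordered; compound 1 gives the lowest number and is separated from both by more than the scatter.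

Compound 4, `Cn1c(=O)c(=O)n(C2CCCC2)c2nc(N/N=C/c3cccc([N+](=O)[O-])c3)ncc21`, is not yet measured. Its change from compound 3 is 3-nitrophenyl in place of 3,4-dimethylphenyl on a carbon with a double bond to nitrogen. Going by the values given here, no measured step involves a nitro group, so the only guidance comes from the other swaps of the aryl group on this carbon: a 4.0-fold higher number from compound 1 to compound 2 (0.60 log units; beyond the scatter) and a 4.4-fold higher number from compound 1 to compound 3 (0.64 log units; beyond the scatter), both modest rises in the number on leaving 4-chlorophenyl, and a 1.1-fold higher number from compound 2 to compound 3 (0.04 log units; within the scatter), which shows that two different substituted phenyl groups at this place gave indistinguishable numbers. On that basis compound 4 is expected to remain close to compound 3, with at most a small shift that may not clear the scatter. The expected step is a 1.5-fold lower number from compound 3 to compound 4 (0.18 log units; within the scatter). For compound 4 in this assay the estimate is 20000 nM, with a range from 8000 nM to 50000 nM.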

Compound 4, half-maximal inhibitory concentration: 12300 nM
Beside the measured number, compound 4's estimate is 1.6-fold (0.21 log units) above it, and the stated range covers the measured number.
By their numbers in this assay, from the lowest: compounds 1 and 4 (each within the scatter of the next); then compounds 2 and 3 (each within the scatter of the next).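

In this assay, nitro in place of methoxy on an aromatic carbon gives a 2.2-fold lower number from compound 2 to compound 4 (0.35 log units; beyond the scatter) and 3-nitrophenyl in place of 3,4-dimethylphenyl gives a 2.5-fold lower number from compound 3 to compound 4 (0.39 log units; beyond the scatter). Going by these compounds alone, compound 2 and compound 3 could not be told apart, so these steps are the first evidence that the number can move beyond the scatter among aryl groups other than 4-chlorophenyl on this carbon. The earlier compounds also left 4-chlorophenyl apart from every other aryl group, but a 1.8-fold higher number from compound 1 to compound 4 (0.25 log units; within the scatter) lies within the scatter, so compound 1 and compound 4 cannot be ordered and 4-chlorophenyl no longer stands alone; no measurement in hand bears on the reason for any of these steps.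

The compounds shown leave open how an unsubstituted phenyl, or a phenyl carrying an amine or a carboxylic acid, would read on this carbon, and so whether any aryl group here reaches a clearly lower number than compound 1 and compound 4 give. The rest of the core is the same in all four compounds, so they say nothing about changes made there.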